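The compounds below may be only part of what the source reports. "The series", "measured", "known", "first", "only" and "open" are said of these compounds alone.

Compound 1, `c1ccc(COc2ccc(Nc3ncnc4cc5c(cc34)OCCOCCOCCO5)cc2)cc1`: in a functional assay on HepG2 cells (Homo sapiens) for antiproliferative activity, read by MTT assay, with a stated time of 72 h (a lower number here means a stronger inhibitor, a higher number a weaker inhibitor), compound 1 gives > 100000 nM, a limit of the assay rather than a number.
Compound 2, `c1ccc(COc2ccccc2Nc2ncnc3cc4c(cc23)OCCOCCOCCO4)cc1`: compound 2 gives 37300 nM.
Compound 3, `FC(F)(F)c1ccc(COc2ccc(Nc3ncnc4cc5c(cc34)OCCOCCOCCOCCO5)cc2)cc1`: compound 3 gives 3340 nM.

Among the two numbers that are numbers, compound 3 stands lowest. Its nearest neighbour is compound 2, whose value lies higher by a gap that is beyond the usual scatter of this assay. The value of compound 1 is only a limit, (the limit of > 100000 nM in this assay, at which 1 of the 3 values shown sits), so its distance from compound 3 cannot be stated.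

Compound 4, `O=[N+]([O-])c1ccc(COc2ccc(Nc3ncnc4cc5c(cc34)OCCOCCOCCOCCO5)cc2)cc1`, has not yet been measured. It differs from compound 3 in one place: nitro in place of trifluoromethyl on an aromatic carbon. Going by the values given here, no pair of measured compounds shows this change, so the size and direction of its step rest on expectation alone. A modest step is expected, with the number for compound 4 staying near that of compound 3 and the direction uncertain; the change a 1.5-fold higher number from compound 3 to compound 4 (0.18 log units; within the scatter) is estimated to fall within or only a little beyond the scatter.

Compound 4 is therefore expected to give about 5000 nM in this assay. The estimate for compound 4 runs from 1500 nM to 20000 nM.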

Compound 4, half-maximal inhibitory concentration: > 100000 nM
Compound 4 was reported as a limit (the forecaster's own chance of this, stated with the estimate: 5%); at least 20-fold (1.30 log units) between middle value and limit.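

The change on this aromatic carbon, para to a large group, is far from neutral: in this assay, nitro in place of trifluoromethyl gives an at least 29-fold higher number from compound 3 to compound 4 (1.47 log units; beyond the scatter), a large step beyond the scatter. Going by these compounds alone, the earlier compounds offered no step between measured compounds that differ in one place, so this pair is the first to show that the group on the 4-substituted benzyl can decide whether a number is read at all. Compound 4 stands at a limit and not at a number, so the step marks only the smallest possible gap and its true size cannot be read: the limit of > 100000 nM in this assay, at which 2 of the 4 values shown sit.

The compounds shown leave open whether this drop is peculiar to nitro, or whether a nitrile, a chlorine atom, a methoxy group or an amine on the same carbon would also end at the limit or would hold a number near that of compound 3. They also leave open whether the same exchange would have a similar effect on the core of compound 1, where the large ring is shorter.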